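The source may hold more compounds than are shown below. What is called first, only, known or untested is meant among the compounds shown, and "the series" means these compounds.

Measured so far in a functional assay on A549 cells (Homo sapiens) for inhibition, read by MTT assay, with a stated time of 48 h; a lower number here means a stronger inhibitor, a higher number a weaker inhibitor:
Compound 1 `COc1ccc2c(=O)c(/C=C/C(=O)Nc3cccc(C)c3)coc2c1` — compound 1 gives > 100000 nM, a limit of the assay rather than a number.
Compound 2 `COc1ccc2c(=O)c(/C=C/C(=O)NCc3ccccc3)coc2c1` — compound 2 gives 11800 nM.
Compound 3 `COc1ccc2c(=O)c(/C=C/C(=O)NCc3ccc(F)cc3)coc2c1` — compound 3 gives > 100000 nM, again a limit of the assay.

Among the measured compounds shown here, compound 2 therefore stands alone: its result is the only actual number among the three, the other two sitting at the limit of > 100000 nM in this assay, at which 2 of the 3 values shown sit. Compound 4 `COc1ccc2c(=O)c(/C=C/C(=O)Nc3ccc(F)cc3)coc2c1` is still to be measured. It differs from compound 2 in one place (4-fluorophenyl in place of benzyl on an amide-type nitrogen). For the measured compounds named here, two measured steps bear on this change. Moving from an aryl group to benzyl on the amide nitrogen gave an at least 8.4-fold lower number from compound 1 to compound 2 (0.92 log units; beyond the scatter), and adding fluoro to that benzyl gave an at least 8.4-fold higher number from compound 2 to compound 3 (0.92 log units; beyond the scatter). The remaining comparison, a step that the two limits leave unreadable from compound 1 to compound 3, gives no size. Compound 4 reverses the first of those moves and adds the second, both of which pointed toward weaker inhibition, so a clear rise in this assay is expected, quite possibly back to the limit. Compound 4 is expected to give 80000 nM, in the range 20000 nM to 300000 nM. The step this estimate means is a 6.8-fold higher number from compound 2 to compound 4 (0.83 log units; beyond the scatter).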

Compound 4, half-maximal inhibitory concentration: 26800 nM
Compound 4: the middle estimate sits 3.0-fold (0.47 log units) above what was measured; the measured number falls inside the stated range.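

In this assay, replacing benzyl with 4-fluorophenyl on the amide-type nitrogen changes the result only modestly, giving a 2.3-fold higher number from compound 2 to compound 4 (0.36 log units; beyond the scatter). The order of aryl and benzyl groups is not fixed, as 4-fluorophenyl outperforms 4-fluorobenzyl, with an at least 3.7-fold lower number from compound 3 to compound 4 (0.57 log units; beyond the scatter), whereas the earlier change from 3-methylphenyl to benzyl favoured benzyl. The two aryl amides also differ, with an at least 3.7-fold lower number from compound 1 to compound 4 (0.57 log units; beyond the scatter), and this step and the one before it give only minimum sizes, because each starts from a compound at the assay limit: the limit of > 100000 nM in this assay, at which 2 of the 4 values shown sit.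

On these data alone, whether a chloro or methoxy group on the benzyl ring would behave as fluoro does remains open. Also open, as far as these compounds go, are how unsubstituted phenyl would compare with these aryl groups and what a longer chain, such as 2-phenylethyl, would do on the same nitrogen.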